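A few compounds are considered here, and "the series" means these few. Any claim that something is new, unique, unknown or untested is made for them only; others in the source may bear on it.

Measured in a functional assay on HeLa cells (Homo sapiens) for antiproliferative activity, read by MTT assay, with a stated time of 72 h; a higher number here means a weaker inhibitor, a lower number a stronger inhibitor:
- Compound 1 `COc1cccc(N2C(=O)COc3ccc(-c4cnc(OC)c(NS(=O)(=O)c5ccc(F)cc5)c4)cc32)c1`: > 40000 nM, a limit of the assay and not a number
- Compound 2 `COc1ncc(-c2ccc3c(c2)N(c2ccc(F)cc2)C(=O)CO3)cc1NS(=O)(=O)c1ccc(F)cc1`: 10500 nM
- Compound 3 `COc1ncc(-c2ccc3c(c2)N(c2ccccc2)C(=O)CO3)cc1NS(=O)(=O)c1ccc(F)cc1`: 1530 nM

Among these three, compound 3 has the lowest number, 1530 nM, which makes it the strongest inhibitor so far. All three share one core and differ only in the group on an amide-type nitrogen in a ring.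

The next compound, compound 4 `COc1ncc(-c2ccc3c(c2)N(C2CC2)C(=O)CO3)cc1NS(=O)(=O)c1ccc(F)cc1`, keeps that core but has cyclopropyl in place of phenyl on that nitrogen: cyclopropyl in place of phenyl on an amide-type nitrogen in a ring.

Among the measured compounds shown here, two measured steps bear on this change, since both alter the same group. Hydrogen in place of methoxy gave an at least 26-fold lower number from compound 1 to compound 3 (1.41 log units; beyond the scatter), and hydrogen in place of fluoro gave a 6.9-fold lower number from compound 2 to compound 3 (0.84 log units; beyond the scatter). Among these compounds, then, the unsubstituted phenyl gives the lowest number. For the measured compounds named here, neither step replaces the phenyl itself, however, and no measured compound lacks an aromatic ring on that nitrogen. These steps therefore do not show which way the new change will go.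

In this assay, no step beyond the scatter is expected, though with wide uncertainty. The expected step is a 1.0-fold lower number from compound 3 to compound 4 (0.01 log units; within the scatter). The estimate for compound 4 is 1500 nM, with an expected range from 300 nM to 8000 nM.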

Compound 4, half-maximal inhibitory concentration: 6030 nM
The estimate for compound 4 lay 4.0-fold (0.60 log units) below the measured number, and the stated range covers the measured number.
By their numbers in this assay, from the lowest: compound 3; then compounds 4 and 2 (each within the scatter of the next). At a limit, above all of these: compound 1.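

In this assay, cyclopropyl in place of phenyl on the amide-type nitrogen gives a 3.9-fold higher number from compound 3 to compound 4 (0.60 log units; beyond the scatter). Among the compounds shown here, this is the first change to the phenyl ring itself: the unsubstituted phenyl of compound 3 keeps the lowest number of the four, yet a measured number remains without an aromatic ring on that nitrogen. Cyclopropyl in place of 4-fluorophenyl gives a 1.7-fold lower number from compound 2 to compound 4 (0.24 log units; within the scatter), so these two groups cannot be told apart here, while cyclopropyl in place of 3-methoxyphenyl gives an at least 6.6-fold lower number from compound 1 to compound 4 (0.82 log units; beyond the scatter), a step read against a limit of the assay for compound 1, not a number: the limit of > 40000 nM in this assay, at which 1 of the 4 values shown sits.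

As far as these compounds go, it remains open whether a group such as methyl, a longer chain, a cyclohexyl ring or a chain ending in an amine on that nitrogen would fall nearer to compound 3 or to compound 4. Also open, from the compounds shown here alone, is how a phenyl ring with another substituent, such as 4-methoxyphenyl or 3-fluorophenyl, would compare with the unsubstituted phenyl.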